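The source may hold more compounds than are shown below. What is called first, only, known or untested is meant among the compounds shown, and "the series" means these compounds.

Of the compounds shown here, three have been measured in an assay on CHO cells for displacement of a labelled ligand from Substance-P receptor (Homo sapiens); a lower number here means a stronger inhibitor, a higher number a weaker inhibitor. Compound 1 `C[C@@H](O[C@@H]1[C@@H](c2ccc(F)cc2)CN2C(=O)OC[C@@H]12)c1cc(C(F)(F)F)cc(C(F)(F)F)c1` gives 0.33 nM, compound 3 `C[C@@H](O[C@H]1CN(C(=O)OC(C)(C)C)[C@@H](CO)[C@@H]1c1ccccc1)c1cc(C(F)(F)F)cc(C(F)(F)F)c1` gives 0.63 nM, and compound 2 `C[C@@H](O[C@H]1CN2C(=O)N(C)C[C@H]2[C@@H]1c1ccc(F)cc1)c1cc(C(F)(F)F)cc(C(F)(F)F)c1` gives 0.88 nM. Compound 2 thus shows the largest number of the three, but its gap to compound 3 lies within the usual scatter, while compound 1 sits clearly lower, beyond it. Compound 4 `C[C@@H](O[C@H]1CN2C(=O)NC[C@H]2[C@@H]1c1ccc(F)cc1)c1cc(C(F)(F)F)cc(C(F)(F)F)c1` differs from compound 2 in one place: hydrogen in place of methyl on an amide-type nitrogen in a ring. Among the compounds with values here, no measured pair shows this change, so there is no step to lean on. A change this small at an amide-type nitrogen in a ring is expected to move the number little, if at all beyond the scatter. Compound 4 is therefore estimated at 0.7 nM, within 0.3 nM to 1.8 nM. The expected step is a 1.3-fold lower number from compound 2 to compound 4 (0.10 log units; within the scatter).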

Compound 4, half-maximal inhibitory concentration: 0.06 nM
Estimate against measurement, compound 4: 12-fold (1.07 log units) above; the whole stated range lies above it.
By their numbers in this assay, from the lowest: compound 4; then compounds 1, 3 and 2 (each within the scatter of the next, the first and the last beyond it).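

In this assay, hydrogen in place of methyl on the amide-type nitrogen in a ring gives a 15-fold lower number from compound 2 to compound 4 (1.17 log units; beyond the scatter), a large step beyond the scatter. The earlier compounds shown here differ in more than one place, so none could show that the loss of this one carbon at this position can matter so much. Nothing measured here explains the size of the step.

The compounds shown leave open how an ethyl group, an acetyl group or a longer chain on this nitrogen would compare with hydrogen and methyl.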